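A few compounds are considered here, and "the series" means these few. Any claim that something is new, unique, unknown or untested is made for them only; others in the source may bear on it.

Measured compounds in a functional assay on NCI-H460 cells (Homo sapiens) for antiproliferative activity, read by MTT assay, with a stated time of 72 h; a higher number here means a weaker inhibitor, a lower number a stronger inhibitor:
compound 1 `CNC(=O)c1cc(Oc2ccc(NC(=O)c3cc4cccnc4n(-c4ccccc4)c3=O)cc2)ccn1`: 320 nM
compound 2 `CNC(=O)c1cc(Oc2ccc(NC(=O)c3cc4cccnc4n(-c4ccc(Cl)cc4)c3=O)cc2)ccn1`: "not determined" (no result reported)
compound 3 `CNC(=O)c1cc(Oc2ccc(NC(=O)c3cc4cccnc4n(-c4ccc(C(F)(F)F)cc4Cl)c3=O)cc2)ccn1`: 2110 nM

Compound 1 holds the lowest of the two numbers in this assay; compound 3 is the nearest, and the step of a 6.6-fold higher number from compound 1 to compound 3 (0.82 log units; beyond the scatter) is beyond the scatter. For compound 2 no number was obtained.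

Compound 4 `CCCNC(=O)c1cc(Oc2ccc(NC(=O)c3cc4cccnc4n(-c4ccccc4)c3=O)cc2)ccn1` differs from compound 1 at one place only: ethyl in place of hydrogen on a saturated chain carbon bound to an amide-type nitrogen. The shared core and the substituent on the aromatic nitrogen are unchanged.

Among the compounds with values here, none of the measured steps bears on this change. Within the data shown here, the one step measured in this assay, from compound 1 to compound 3, alters the group on the aromatic nitrogen, far from the amide chain, and it says nothing about lengthening the amide chain. Among the measured compounds shown here, with no comparable step in hand, the working expectation is a step within the scatter, in no particular direction. For compound 4 the expected value is 400 nM (range 150 nM to 1100 nM), which corresponds to an estimated step of a 1.3-fold higher number from compound 1 to compound 4 (0.10 log units; within the scatter).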

Compound 4, half-maximal inhibitory concentration: 110 nM
Compound 4: middle estimate off by 3.6-fold (0.56 log units), on the high side, and the stated range ends above it.
By their numbers in this assay, from the lowest: compound 4; then compound 1; then compound 3.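

In this assay, the methylcarbamoyl to propylcarbamoyl change gives a 2.9-fold lower number from compound 1 to compound 4 (0.46 log units; beyond the scatter), so the saturated chain on the amide-type nitrogen is a place where the number moves beyond the scatter, and here it moves down. The only earlier step changed the group on the aromatic nitrogen and raised the number, so this is the first change shown to lower it from compound 1. No measurement shown explains the lower number of compound 4.

As far as these compounds go, with only methyl and propyl at this place, it remains open whether a longer chain such as butyl, a ring such as cyclopropyl, or a chain ending in an amine or a carboxylic acid would lower the number further. From the compounds shown here alone, whether propyl gives a similar step with 2-chloro-4-(trifluoromethyl)phenyl on the aromatic nitrogen also remains open.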